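Clearance from compound 3 to compound 4: an estimate

The source may report more compounds than this note shows. Statements on the series, on what has been measured and on what is new or still open speak of the compounds shown alone.

Measured in an in vitro ADME assay on microsomes from liver (Mus musculus) for pharmacokinetics, read by LC-MS, with a stated time of 10 min, tested at 1 uM; on this read-out lower numbers stand for slow clearance and higher numbers for fast clearance:
- compound 1 `CC(C)c1ccc(NC(=O)[C@H]2CN(C)C[C@@H]2c2ccc(/C=C/C(=O)Nc3ccccc3N)cc2)cc1`: 54 mL/min/kg
- compound 2 `CN1C[C@H](C(=O)Nc2cccc(F)c2)[C@@H](c2ccc(/C=C/C(=O)Nc3ccccc3N)cc2)C1`: 56 mL/min/kg
- compound 3 `Cc1cc(NC(=O)[C@H]2CN(C)C[C@@H]2c2ccc(/C=C/C(=O)Nc3ccccc3N)cc2)ccc1Cl`: 65 mL/min/kg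

Compound 3 gives 65 mL/min/kg in this assay, a number within the scatter of the other two compounds. Compound 4 `CN1C[C@H](C(=O)Nc2ccc(F)cc2F)[C@@H](c2ccc(/C=C/C(=O)Nc3ccccc3N)cc2)C1` has not yet been measured. Its difference from compound 3 is 2,4-difluorophenyl in place of 4-chloro-3-methylphenyl on an amide-type nitrogen.

For the measured compounds named here, three measured steps bear on this change, all at that same place: a 1.0-fold higher number from compound 1 to compound 2 (0.02 log units; within the scatter), a 1.2-fold higher number from compound 1 to compound 3 (0.08 log units; within the scatter) and a 1.2-fold higher number from compound 2 to compound 3 (0.06 log units; within the scatter). Each of them stays within the scatter. Compound 2, with 3-fluorophenyl at this place, gives 56 mL/min/kg. Going by the values given here, no measured compound carries 2,4-difluorophenyl, so the group itself is untested. No step beyond the scatter is therefore expected in this assay, and no clear direction can be expected either. The expected step is a 1.1-fold lower number from compound 3 to compound 4 (0.05 log units; within the scatter). For compound 4 the estimated clearance is 58 mL/min/kg, with an expected range from 36 mL/min/kg to 90 mL/min/kg.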

Compound 4, clearance: 27 mL/min/kg
Beside the measured number, compound 4's estimate is 2.1-fold (0.33 log units) above it; measured number outside the range, below it.
By their numbers in this assay, from the lowest: compounds 4, 1, 2 and 3 (each within the scatter of the next, the first and the last beyond it).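

In this assay, for the compounds shown here, the amide-type nitrogen position no longer looks indifferent: the three earlier aryl groups stayed within the scatter of one another, whereas 2,4-difluorophenyl gives the first steps beyond it, a 2.4-fold lower number from compound 3 to compound 4 (0.38 log units; beyond the scatter) and a 2.1-fold lower number from compound 2 to compound 4 (0.32 log units; beyond the scatter). Fluorine on this ring does not by itself set the number, since the 3-fluorophenyl of compound 2 and the 2,4-difluorophenyl of compound 4 read apart, while a 2.0-fold lower number from compound 1 to compound 4 (0.30 log units; within the scatter) stays within the scatter, so compound 4 stands clearly apart from only two of the three. Nothing shown explains this shift.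

The compounds shown leave open whether the shift needs both fluorines of 2,4-difluorophenyl or would persist with just one of them. They also leave open how a nitrile or an amine on this phenyl ring would read.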